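Methyl on the ring carbon: compound 3 to compound 4

This account rests on a few compounds, and the source may have more. Where it says the series, first, only, none or still open, it means among the compounds named here.

Compound 1 `C[Si](C)(C)CCOCn1c(CC(O)(COCc2ccccc2)COCc2ccccc2)cc(=O)[nH]c1=O`, compound 2 `Cc1c(CC(O)COCc2ccccc2)[nH]c(=O)[nH]c1=O` and compound 3 `C[Si](C)(C)CCOCn1c(CC(O)COCc2ccccc2)cc(=O)[nH]c1=O` share a core with a benzyloxy-bearing side chain, and all three sit at the ceiling of a functional assay on SW-620 cells (Homo sapiens) for antiproliferative activity, read by MTT assay, with a stated time of 72 h; on this read-out lower numbers stand for stronger inhibition and higher numbers for weaker inhibition. Compound 1 gives > 100000 nM, a limit of the assay and not a number. Compound 2 gives > 100000 nM, also a limit. Compound 3 gives > 100000 nM, again a limit, so its standing among the numbers shown is only that it is indistinguishable from the other two at the ceiling. For the measured compounds named here, the single one-place step, a step that the two limits leave unreadable from compound 1 to compound 3, runs between two entries at the limit of > 100000 nM in this assay, at which 3 of the 3 values shown sit, and yields no size. Compound 4 `Cc1c(CC(O)COCc2ccccc2)n(COCC[Si](C)(C)C)c(=O)[nH]c1=O` differs from compound 3 by methyl in place of hydrogen on an aromatic carbon. Going by the values given here, no measured step bears on this change. Compound 2 carries the same methyl on its core and sits at the limit. The step expected from this change, a step that the limit leaves unreadable from compound 3 to compound 4, is none beyond the scatter. Compound 4 is expected at 150000 nM, with a range from 50000 nM to 600000 nM, most likely reported only as a limit.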

Compound 4, half-maximal inhibitory concentration: > 100000 nM
Compound 4: a limit, no number; the forecaster's own chance of this, stated with the estimate: 85%; the middle value lies beyond the limit too.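

In this assay, for the compounds shown here, compound 4 gives > 100000 nM as a limit and not a number, and no step to it from compound 2 or compound 3 can be read. The compounds shown leave open what the methyl on the aromatic carbon does to the read-out, with no measured number yet in the series: the limit of > 100000 nM in this assay, at which 4 of the 4 values shown sit.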